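Hexyloxy for Bromo on the Sulfonamide Aniline Ring

The source may report more compounds than this note shows. Statements on the series, on what has been measured and on what is new or still open speak of the compounds shown alone.

Compound 1 `CCCCCc1ccc(NS(=O)(=O)c2ccc(N3CCNC3=O)cc2)cc1` gives > 1000 nM in a functional assay on MCF7 cells (Homo sapiens) for antiproliferative activity, read by sulforhodamine B assay, with a stated time of 48 h (a higher number here means a weaker inhibitor, a lower number a stronger inhibitor), a limit of the assay rather than a number.
Compound 2 `CC(C)Cc1ccc(NS(=O)(=O)c2ccc(N3CCNC3=O)cc2)cc1` gives > 1000 nM in this assay, again a limit.
Compound 3 `O=C1NCCN1c1ccc(S(=O)(=O)Nc2ccc(Br)cc2)cc1` gives 240 nM in this assay.

Among the measured compounds shown here, compound 3 holds the only number among the three values shown; the other two sit at a limit (the limit of > 1000 nM in this assay, at which 2 of the 3 values shown sit). Compound 4 `CCCCCCOc1ccc(NS(=O)(=O)c2ccc(N3CCNC3=O)cc2)cc1` differs from compound 3 by hexyloxy in place of bromo on an aromatic carbon. For the measured compounds named here, the steps that bear on this change are an at least 4.1-fold lower number from compound 1 to compound 3 (0.61 log units; beyond the scatter) and an at least 4.1-fold lower number from compound 2 to compound 3 (0.61 log units; beyond the scatter): each replaces a saturated carbon chain on that aromatic carbon with bromo and gives a lower number, so the reverse direction, a chain entering where bromo leaves, points toward a higher number. A hexyloxy chain is longer than either pentyl or isobutyl, and the step that the two limits leave unreadable from compound 1 to compound 2 between the two chains cannot be read. Compound 4 is therefore expected to give a 6.3-fold higher number from compound 3 to compound 4 (0.80 log units; beyond the scatter) in this assay. Compound 4 is estimated at 1500 nM, within a range from 400 nM to 6000 nM, with a fair chance that only a limit is reported.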

Compound 4, half-maximal inhibitory concentration: > 1000 nM
Compound 4: a limit, no number; the forecaster's own chance of this, stated with the estimate: 55%; the middle value is on the limit's open side.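

Hexyloxy in place of bromo gives an at least 4.1-fold higher number from compound 3 to compound 4 (0.61 log units; beyond the scatter) in this assay, so the step away from bromo on this aromatic carbon is now read directly. Compound 4 gives only a limit, which shows that a chain joined through oxygen, and not only the all-carbon pentyl and isobutyl chains, leaves this position without a measured number. The steps from compound 1 and from compound 2 to compound 4 cannot be read, so the three chains cannot be ranked, and the series now rests largely on limits: the limit of > 1000 nM in this assay, at which 3 of the 4 values shown sit.

As far as these compounds go, how far beyond the limit the three chain compounds lie remains open, as does whether the oxygen or the chain itself matters more. Also open, from the compounds shown here alone, is what a methoxy group, a chlorine or an amine would give on this aromatic carbon.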